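Sulfonyl to acetyl on the aminotetralin-imidazole core

The source may hold more compounds than are shown below. What is called first, only, known or untested is meant among the compounds shown, and "the series" means these compounds.

Measured compounds: compound 1 `CN(c1cccc2c1CCCC2c1c[nH]cn1)S(C)(=O)=O` gives 204 nM; compound 2 `CC(C)S(=O)(=O)Nc1cccc2c1CCCC2c1c[nH]cn1` gives 1150 nM; compound 3 `O=S(=O)(Nc1cccc2c1CCCC2c1c[nH]cn1)C1CC1` gives 537 nM, all in an assay on isolated protein for binding affinity to Alpha-1A adrenergic receptor (Rattus norvegicus), read by radioligand binding; a lower number here means a stronger inhibitor, a higher number a weaker inhibitor.

Compound 3 stands second highest of the three numbers in this assay; it lies a 2.6-fold higher number from compound 1 to compound 3 (0.42 log units; beyond the scatter) and a 2.1-fold lower number from compound 2 to compound 3 (0.33 log units; beyond the scatter). Compound 4 `CC(=O)Nc1cccc2c1CCCC2c1c[nH]cn1` differs from compound 3 by acetyl in place of cyclopropylsulfonyl on a nitrogen on an aromatic ring. Within the data shown here, every measured step varies only the group on the sulfonyl sulfur, none replaces the sulfonyl itself, so no step bears directly on this change; the steps seen were modest, and a modest step in either direction, or none beyond the scatter, is expected. Compound 4 is therefore estimated at 700 nM, with a range of 200 nM to 2500 nM, a step of a 1.3-fold higher number from compound 3 to compound 4 (0.12 log units; within the scatter).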

Compound 4, inhibition constant: 525 nM
The estimate for compound 4 lay 1.3-fold (0.12 log units) above the measured number, within the range that was stated.
By their numbers in this assay, from the lowest: compound 1; then compounds 4 and 3 (each within the scatter of the next); then compound 2.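

In this assay the sulfonyl itself proves replaceable on this nitrogen, with a 1.0-fold lower number from compound 3 to compound 4 (0.01 log units; within the scatter) as the reading for acetyl in place of cyclopropylsulfonyl, despite the smaller group. The other two steps match what the sulfonyl series already showed, with a 2.2-fold lower number from compound 2 to compound 4 (0.34 log units; beyond the scatter) on one side and a 2.6-fold higher number from compound 1 to compound 4 (0.41 log units; beyond the scatter) on the other. Nothing measured here explains this result.

As far as these compounds go, whether a methyl on the nitrogen of compound 4 would give the lower number of compound 1 remains open. So does the outcome for a urea or a longer acyl chain at this nitrogen.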